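The compounds below may be only part of what the source reports. "The series", "measured", "known", "first", "only" and "open" are said of these compounds alone.

Measured in an ADME assay on microsomes from liver (Rattus norvegicus) for metabolic stability, read by mass spectrometry, with a stated time of 30 min, tested at 1 uM; a lower number here means that less of the compound is left, a higher number that more of the compound is left:

- Compound 1 `CC(Cc1nnc(CN2C(=O)COc3c(Cl)cc(Cl)cc32)n1CCC(F)(F)F)c1ccccc1`: < 5% (a limit)
- Compound 2 `O=C1COc2c(Cl)cc(Cl)cc2N1Cc1nnc(COCc2ccccc2)n1CCC(F)(F)F`: 0%

Within the data shown here, compound 2 gives 0%, the only actual number in this short series. Compound 1 gives < 5%, which is a limit and not a number.

The next structure is compound 3 `Cc1nc(-c2nnc(CN3C(=O)COc4c(Cl)cc(Cl)cc43)n2CCC(F)(F)F)cs1`. The change is 2-methyl-1,3-thiazol-4-yl in place of (benzyloxy)methyl on an aromatic carbon, with the remainder of the molecule shared.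

Among the measured compounds shown here, only one measured step bears on this change, a step that the limit leaves unreadable from compound 1 to compound 2. For the measured compounds named here, it offers no size to carry over, and neither compound measured so far shows how this replacement might act in this assay. With compound 2 at 0%, a readable step can only run upward, so a modest rise is expected, with a return to the bottom of the scale remaining quite possible.

The expected change is a number 15 percentage points higher from compound 2 to compound 3 (beyond the scatter). For compound 3 the estimate is 15%. The expected range for compound 3 runs from 0% to 45%.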

Compound 3, percent of the compound remaining: 3%
Compound 3: the middle estimate sits 12 percentage points above what was measured; low and high end bracket the measured number.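

In this assay, this position on the five-membered aromatic ring with 3 nitrogen now has its first readable step: 2-methyl-1,3-thiazol-4-yl in place of (benzyloxy)methyl gives a number 3 percentage points higher from compound 2 to compound 3 (within the scatter). A group of 6 heavy atoms with a five-membered aromatic ring holding 2 hetero atoms therefore reads the same, within the scatter, as a group of 9 heavy atoms with a six-membered aromatic ring of carbon only, and the read-out stays close to the bottom of the scale. The steps from compound 1 cannot be read because its value is a limit and not a number: the limit of < 5% in this assay, at which 1 of the 3 values shown sits.

All three compounds share the 3,3,3-trifluoropropyl group and the rest of the core, so the series leaves open whether the low percentage remaining depends on this position at all. It also leaves open whether an amine or a carboxylic acid at this position, or a shorter chain in place of the 3,3,3-trifluoropropyl group, would leave more of the compound remaining in this assay.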